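The source may report more compounds than this note shows. Statements on the series, on what has been measured and on what is new or still open speak of the compounds shown alone.

Compound 3 `Cc1cc(C)c(NC(=O)N(Cc2cccc(-c3nnn(C)n3)c2)C2CCCCCC2)c(C)c1` gives 100 nM in an assay on microsomes from intestine for inhibition of acyl-CoA:cholesterol acyltransferase (Oryctolagus cuniculus); a higher number here means a weaker inhibitor, a lower number a stronger inhibitor. Of the two numbers shown it holds the low end, with compound 1 `Cc1cc(C)c(NC(=O)N(Cc2cccc(-c3csc(C)n3)c2)C2CCCCCC2)c(C)c1` nearest at 180 nM, the pair separated by only a 1.8-fold lower number from compound 1 to compound 3 (0.26 log units; within the scatter). Compound 2 `Cc1cc(C)c(NC(=O)N(Cc2cccc(-c3nn[nH]n3)c2)C2CCCCCC2)c(C)c1` reaches only the limit of this assay at > 1000 nM; this is the limit of > 1000 nM in this assay, at which 1 of the 3 values shown sits. From that limit, an at least 10-fold lower number from compound 2 to compound 3 (1.00 log units; beyond the scatter) was recorded, and an at least 5.5-fold higher number from compound 1 to compound 2 (0.74 log units; beyond the scatter) describes the other side of the same position.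

Compound 4 `Cc1cc(C)c(NC(=O)N(Cc2cccc(-n3cccc3)c2)C2CCCCCC2)c(C)c1` carries the change (1H-pyrrol-1-yl in place of 2-methyl-2H-tetrazol-5-yl on an aromatic carbon). Among the compounds with values here, none of the measured steps makes this exact exchange, but both measured steps at this position bear on it: replacing the methylthiazolyl ring with the free tetrazole cost an at least 5.5-fold higher number from compound 1 to compound 2 (0.74 log units; beyond the scatter), whereas the methyl-capped tetrazole was indistinguishable from the thiazole within scatter. Since the pyrrolyl ring, like the methylthiazolyl and methyltetrazolyl rings, carries no hydrogen-bond donor, no step beyond the scatter is expected, though some loss is possible given that the substituent is smaller. For compound 4 the number expected in this assay is 200 nM, with a range from 60 nM to 700 nM. That estimate corresponds to an expected step of a 2.0-fold higher number from compound 3 to compound 4 (0.30 log units; within the scatter).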

Compound 4, half-maximal inhibitory concentration: 20 nM
Compound 4: the middle estimate sits 10-fold (1.00 log units) above what was measured; measured number below the stated range.
By their numbers in this assay, from the lowest: compound 4; then compounds 3 and 1 (each within the scatter of the next). At a limit, above all of these: compound 2.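

In this assay, the 1H-pyrrol-1-yl ring sets compound 4 apart from both earlier rings without a hydrogen-bond donor, with a 5.0-fold lower number from compound 3 to compound 4 (0.70 log units; beyond the scatter) and a 9.0-fold lower number from compound 1 to compound 4 (0.95 log units; beyond the scatter), whereas those two rings could not be separated from each other. Among the compounds shown, then, capping the donor does not settle the matter: the number still moves with the identity of the ring on this aromatic carbon, and the exchange from compound 3, which leaves 1 hydrogen-bond acceptor in place of 4 and a single hetero atom in the ring, gives the lowest number of the series. The step of an at least 50-fold lower number from compound 2 to compound 4 (1.69 log units; beyond the scatter) is only a bound, for compound 2 stands at a limit of the assay: the limit of > 1000 nM in this assay, at which 1 of the 4 values shown sits.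

The compounds shown leave open whether the lower number follows the loss of ring hetero atoms, a question on which a plain phenyl ring or a 1H-imidazol-1-yl group at this place would bear. They also leave open whether the same step would carry over with the rest of the shared core altered.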